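Swapping the aryl group on the best-measured compound

The compounds below may be only part of what the source reports. "The series", "measured", "known", "first", "only" and "open" are said of these compounds alone.

Measured in a functional assay on the whole organism with Rattus norvegicus as the target; a lower number here means that less compound is needed, a higher number that more compound is needed for the effect:
Compound 1 (`Cc1ccccc1OCC(O)CNCC(=O)Nc1ccc(C2=NNC(=O)CC2C)cc1`) gives 2.7 umol/kg
Compound 2 (`Cc1ccccc1OCC(O)CNCCC(=O)Nc1ccc(C2=NNC(=O)CC2)cc1`) gives 6 umol/kg
Compound 3 (`Cc1ccccc1OCC(O)CNCCC(=O)Nc1ccc(C2=NNC(=O)CC2C)cc1`) gives 2 umol/kg

Compound 3 (2 umol/kg) cannot be told apart from compound 1 (2.7 umol/kg), while compound 2 (6 umol/kg) lies clearly higher. Compound 4 (`COCCc1ccc(OCC(O)CNCCC(=O)Nc2ccc(C3=NNC(=O)CC3C)cc2)cc1`) carries 4-(2-methoxyethyl)phenyl in place of 2-methylphenyl on an oxygen on a saturated carbon. Within the data shown here, the only measured step (a 3.0-fold lower number from compound 2 to compound 3 (0.48 log units; beyond the scatter)) is a different change, methyl in place of hydrogen on a saturated ring carbon. It therefore gives neither size nor direction here, and the expectation is no shift beyond the scatter in this assay, though with wide uncertainty. The expected change is a 1.5-fold higher number from compound 3 to compound 4 (0.18 log units; within the scatter) and no more. Compound 4 is expected at 3 umol/kg (estimated range 0.8 umol/kg to 11 umol/kg).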

Compound 4, dose for half-maximal effect: 6 umol/kg
Estimate against measurement, compound 4: 2.0-fold (0.30 log units) below; the measured number falls inside the stated range.
By their numbers in this assay, from the lowest: compounds 3 and 1 (each within the scatter of the next); then compounds 2 and 4 (each within the scatter of the next).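

Among the compounds shown, this is the only change to the aryl group on the oxygen, and in this assay replacing 2-methylphenyl with 4-(2-methoxyethyl)phenyl gives a 3.0-fold higher number from compound 3 to compound 4 (0.48 log units; beyond the scatter). This group is therefore not a free place for change: the larger group needs more compound for the effect. No measured evidence bears on the reason for this shift.

Going by these compounds, the swap removes one group and adds another, so the contribution of each stays open. An unsubstituted phenyl, or a phenyl carrying a short methoxy group or an amine, could help separate them.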